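The compounds below may be only part of what the source reports. "The series", "measured", "known", "first", "only" and "open" are said of these compounds alone.

Four compounds built on a shared skeleton were examined in a functional assay on LM7 cells (Homo sapiens) for antiproliferative activity, read by MTT assay, with a stated time of 72 h; on this read-out lower numbers stand for stronger inhibition and higher numbers for weaker inhibition. Compound 2 `Cc1ccc2c(=O)c(CSC(=S)N3CCCC3)coc2c1` and compound 1 `Cc1ccc2c(=O)c(CSC(=S)N3CCCCC3)coc2c1` differ in one place only: piperidin-1-yl in place of pyrrolidin-1-yl on a thiocarbonyl carbon In this assay compound 2 gives 3400 nM, and compound 1 gives 5100 nM, so that the step of a 1.5-fold higher number from compound 2 to compound 1 (0.18 log units; within the scatter). Compound 3 `COc1ccc2occ(CSC(=S)N3CCCC3)c(=O)c2c1` carries another core; the difference between the core of compound 3 and the core of compound 2 is not broken down here. In this assay compound 3 gives 6000 nM, a number that lies close to those of compound 1 and compound 2.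

Compound 4 `COc1ccc2occ(CSC(=S)N3CCCCC3)c(=O)c2c1` has not yet been measured. It stands to compound 3 as compound 1 stands to compound 2: piperidin-1-yl in place of pyrrolidin-1-yl on a thiocarbonyl carbon The place of the change is described in the same words for both pairs, so this is the same change, made for the second time among these compounds. Because the step of a 1.5-fold higher number from compound 2 to compound 1 (0.18 log units; within the scatter) stayed within the scatter, a step of about the same size is estimated for compound 4, namely a 1.5-fold higher number from compound 3 to compound 4 (0.18 log units; within the scatter), and this rests on that single earlier pair alone. On that basis compound 4 is expected to give 9000 nM in this assay, with a likely range from 4500 nM to 18000 nM.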

Compound 4, half-maximal inhibitory concentration: 4700 nM
The estimate for compound 4 lay 1.9-fold (0.28 log units) above the measured number; measured number inside the range.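

On the other core, the change of piperidin-1-yl in place of pyrrolidin-1-yl on a thiocarbonyl carbon gives a 1.3-fold lower number from compound 3 to compound 4 (0.11 log units; within the scatter) in this assay. Although the two steps point in opposite directions on paper, they agree as far as such measurements can tell, so that direction should not be read as real: the same change on two cores in this assay, a 1.5-fold higher number (0.18 log units; within the scatter) from compound 2 to compound 1 and a 1.3-fold lower number (0.11 log units; within the scatter) from compound 3 to compound 4, 1.9-fold (0.28 log units) apart, within the scatter of two such steps. This shows that, on the two cores seen here, exchanging the five-membered ring for the six-membered one leaves the number within the noise of the assay, so the change carries over in the plain sense that neither core shows a clear step; it does not show that the change has a fixed size, that it has no effect at all, or that the same would hold on a third core, as two small steps from one assay cannot settle any of these.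

The compounds shown leave open whether a morpholine ring or an open-chain diethylamine in the place of these two rings would move the number beyond the scatter. They also leave open whether a core carrying a chlorine atom instead of the methyl or methoxy group would respond to the ring change in the same way.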